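Ethyl on the hydroxy oxygen of compound 2

The source may report more compounds than this note shows. Statements on the series, on what has been measured and on what is new or still open speak of the compounds shown alone.

In a functional assay on MDA-MB-231 cells (Homo sapiens) for antiproliferative activity, read by MTT assay, with a stated time of 48 h (on this read-out higher numbers stand for weaker inhibition of growth and lower numbers for stronger inhibition of growth), compound 1 (`COC(=O)N1N=C(c2ccc(OC)cc2)CC1c1cc(OC)c(OC)c(OC)c1`) gives 1990 nM and compound 2 (`COC(=O)N1N=C(c2cccc(O)c2)CC1c1cc(OC)c(OC)c(OC)c1`) gives 740 nM (the lower of the two numbers). Compound 3 (`CCOc1cccc(C2=NN(C(=O)OC)C(c3cc(OC)c(OC)c(OC)c3)C2)c1`) has ethyl in place of hydrogen on an oxygen on an aromatic ring, so 3-hydroxyphenyl becomes 3-ethoxyphenyl (ethyl in place of hydrogen on an oxygen on an aromatic ring). Within the data shown here, the one measured step that bears on this is a 2.7-fold lower number from compound 1 to compound 2 (0.43 log units; beyond the scatter) with 3-hydroxyphenyl replacing 4-methoxyphenyl. Read in reverse, it is only a loose guide, since the two changes are not the same. A modest rise is expected (a 2.0-fold higher number from compound 2 to compound 3 (0.31 log units; beyond the scatter)). In this assay the estimate for compound 3 is 1500 nM (range 600 nM to 4000 nM).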

Compound 3, concentration for 50% growth inhibition: 190 nM
Compound 3: the middle estimate sits 7.9-fold (0.90 log units) above what was measured; the measured number lies below the stated range.
By their numbers in this assay, from the lowest: compound 3; then compound 2; then compound 1.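

In this assay putting ethyl on the hydroxy oxygen did not lower growth inhibition: the change gives a 3.9-fold lower number from compound 2 to compound 3 (0.59 log units; beyond the scatter) and shows that a free hydrogen on this oxygen is not needed for the lower number. Measured against 4-methoxyphenyl, 3-ethoxyphenyl gives a 10-fold lower number from compound 1 to compound 3 (1.02 log units; beyond the scatter) and is the only large step among these compounds. Nothing measured here accounts for the effect of ethyl at this oxygen. As far as these compounds go, whether methoxy or a longer chain such as propyl or butyl on this oxygen would give a lower or a higher number than ethyl stays open. So does whether an amine at the end of such a chain would be tolerated.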